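A few compounds are considered here, and "the series" means these few. Any claim that something is new, unique, unknown or untested is made for them only; others in the source may bear on it.

Three compounds share one core and differ only in the group attached to one carbonyl carbon. Compound 1 `CC(C)(C)OC(=O)N1CCC[C@@H]1C(=O)N1CCC(NS(=O)(=O)c2cc(S(=O)(=O)c3ccccc3)ccc2C(F)(F)F)CC1` gives 120 nM in an assay on isolated protein for binding affinity to secreted frizzled-related protein 1 (Homo sapiens), read by fluorescence; a higher number here means a weaker inhibitor, a lower number a stronger inhibitor. Compound 2 `CC(=O)N1CCC[C@H]1C(=O)N1CCC(NS(=O)(=O)c2cc(S(=O)(=O)c3ccccc3)ccc2C(F)(F)F)CC1` gives 160 nM in this assay, and compound 3 `CN(C)CC(=O)N1CCC[C@H]1C(=O)N1CCC(NS(=O)(=O)c2cc(S(=O)(=O)c3ccccc3)ccc2C(F)(F)F)CC1` gives 90 nM. Compound 3 holds the lowest of the three numbers, yet its gap to each of the others sits within the usual scatter: a 1.3-fold lower number from compound 1 to compound 3 (0.12 log units; within the scatter) and a 1.8-fold lower number from compound 2 to compound 3 (0.25 log units; within the scatter). Compound 4 `CCNC(=O)N1CCC[C@H]1C(=O)N1CCC(NS(=O)(=O)c2cc(S(=O)(=O)c3ccccc3)ccc2C(F)(F)F)CC1` has not yet been measured in this assay. It differs from compound 3 by ethylamino in place of (dimethylamino)methyl on a carbonyl carbon. For the measured compounds named here, the steps that bear on this change are the three measured exchanges at the same place, a 1.3-fold higher number from compound 1 to compound 2 (0.12 log units; within the scatter), a 1.3-fold lower number from compound 1 to compound 3 (0.12 log units; within the scatter) and a 1.8-fold lower number from compound 2 to compound 3 (0.25 log units; within the scatter), none of which moved the number beyond the scatter. A further exchange at this place is therefore expected to leave the number roughly where it stands, with no step beyond the scatter in either direction: a 1.4-fold higher number from compound 3 to compound 4 (0.16 log units; within the scatter). Compound 4 is expected to give about 130 nM, with a likely range from 60 nM to 300 nM.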

Compound 4, half-maximal inhibitory concentration: 30 nM
For compound 4 the middle estimate is 4.3-fold (0.64 log units) above the measured one; the whole stated range lies above it.
By their numbers in this assay, from the lowest: compound 4; then compounds 3, 1 and 2 (each within the scatter of the next).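

In this assay this place proves sensitive after all: ethylamino in place of (dimethylamino)methyl gives a 3.0-fold lower number from compound 3 to compound 4 (0.48 log units; beyond the scatter) and is the first exchange here shown to move the number beyond the scatter. Ethylamino in place of methyl gives a 5.3-fold lower number from compound 2 to compound 4 (0.73 log units; beyond the scatter) and 1-(ethylcarbamoyl)pyrrolidin-2-yl in place of 1-(tert-butoxycarbonyl)pyrrolidin-2-yl gives a 4.0-fold lower number from compound 1 to compound 4 (0.60 log units; beyond the scatter) so compound 4 is the strongest of the four. Ethylamino carries a hydrogen-bond donor that (dimethylamino)methyl lacks, but nothing available ties the lower number to that difference or to any other feature of the group.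

The compounds shown leave open whether dimethylamino placed directly on the carbonyl carbon, with no amide hydrogen, would keep the lower number. They also leave open whether methylamino or a longer chain such as propylamino would lower it further or lose the gain.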